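This account rests on a few compounds, and the source may have more. Where it says the series, first, only, none or still open, it means among the compounds named here.

Compound 1 `COc1cc(Cl)cc(-c2nn(-c3cccc(NC(=O)Nc4cc(C(F)(F)F)cc(C(F)(F)F)c4)c3)cc2-c2ccncc2)c1`: -40%
Compound 2 `COc1cc(Cl)cc(-c2nn(-c3cccc(NC(=O)Nc4ccc(Cl)c(Cl)c4)c3)cc2-c2ccncc2)c1`: -18%

Going by the values given here, in a functional assay on MDA-MB-468 cells (Homo sapiens) for inhibition, read by sulforhodamine B assay, with a stated time of 48 h, tested at 100 uM (a lower number here means a stronger effect, a higher number a weaker effect of the compound at the concentration tested), compound 2 stands at the higher of the two numbers measured so far. The nearest of them, compound 1, lies lower than compound 2 by more than the usual scatter of such measurements, so the two compounds are clearly separated in this assay.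

Compound 3 `COc1cc(Cl)cc(-c2nn(-c3cccc(NC(=O)Nc4cccc(C(F)(F)F)c4)c3)cc2-c2ccncc2)c1` has not yet been measured in this assay. It differs from compound 2 in one place: 3-(trifluoromethyl)phenyl in place of 3,4-dichlorophenyl on an amide-type nitrogen. Among the compounds with values here, no step between measured compounds isolates this change, and two values give no direction for it, so nothing here points firmly up or down. The step expected is a number 7 percentage points lower from compound 2 to compound 3 (within the scatter), a size within the scatter that could turn out in either direction. Compound 3 is therefore estimated to give -25% in this assay, with a range from -50% to 0%.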

Compound 3, a percentage reported as activity, at one concentration (the size of the read-out at that concentration, not a potency): -34%
The estimate for compound 3 lay 9 percentage points above the measured number; measured number inside the range.
By their numbers in this assay, from the lowest: compounds 1 and 3 (each within the scatter of the next); then compound 2.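

In this assay, the group on the amide-type nitrogen now has a one-place comparison: 3-(trifluoromethyl)phenyl in place of 3,4-dichlorophenyl gives a number 16 percentage points lower from compound 2 to compound 3 (beyond the scatter), so the read-out at this place responds to this exchange of aryl groups. Hydrogen in place of trifluoromethyl on an aromatic carbon gives a number 6 percentage points higher from compound 1 to compound 3 (within the scatter), so compound 1 and compound 3 cannot be told apart here. Nothing measured alongside these numbers explains either step.

The compounds shown leave open how an aryl group carrying a nitrile, an amine or a carboxylic acid would read on this nitrogen. They also leave open whether the exchange of 3,4-dichlorophenyl for 3-(trifluoromethyl)phenyl gives a similar step on any other core, since it is seen on this shared core only.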